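The source may hold more compounds than are shown below. What is called first, only, known or untested is meant among the compounds shown, and "the series" means these compounds.

In an ADME assay on J774 cells (Mus musculus) for cytotoxicity (on this read-out lower numbers stand for an effect already at smaller amounts and higher numbers for an effect only at larger amounts of compound), compound 1 (`CCCCc1cc2c(=O)c(CC)c[nH]c2cc1OCCOc1ccccc1`) gives 360 nM and compound 2 (`COC(=O)c1c[nH]c2cc(OCc3ccccc3)ccc2c1=O`) gives 18900 nM on the same measure. Compound 1 therefore holds the lower of the two numbers, and the gap between them lies well beyond the usual scatter of repeated measurements. The two compounds differ in several places at once, so this gap cannot be pinned on any single group.

Compound 3 (`CCCCc1cc2c(=O)cc[nH]c2cc1OCCOc1ccccc1`) stays much closer to compound 1, with a single change: hydrogen in place of ethyl on an aromatic carbon. For the measured compounds named here, no measured pair yet shows what a change of this kind does in this assay, so any forecast must remain loose. A moderate step towards a higher number is the likeliest outcome, which would mean an effect only at larger amounts of compound, although a step within the scatter would be no surprise. In numbers, the expected move is a 3.3-fold higher number from compound 1 to compound 3 (0.52 log units; beyond the scatter) on this read-out. The expected value for compound 3 is 1200 nM (estimated range 250 nM to 6000 nM).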

Compound 3, half-maximal effective concentration: > 20000 nM
Compound 3 ended at the assay's limit (the forecaster's own chance of this, stated with the estimate: 5%); middle value at least 16-fold (1.22 log units) away from the limit.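

For the compounds shown here, this is the first pair that differs in only one place, so a change in this assay can now be tied to the ethyl group on this aromatic carbon: replacing it with hydrogen gives an at least 55-fold higher number from compound 1 to compound 3 (1.74 log units; beyond the scatter). For compound 3 the value > 20000 nM is a limit of the assay and not a number, so the step marks only the smallest size the change can have: the limit of > 20000 nM in this assay, at which 1 of the 3 values shown sits. Even with that limit, the pair shows that this one carbon position is far from neutral on this read-out, as losing just the ethyl group moves the cytotoxic effect of compound 1 to much larger amounts of compound.

Going by these compounds, only ethyl and hydrogen can be compared on this carbon, so it remains open whether the effect needs ethyl itself or would also appear with a methyl group, a longer chain such as propyl, an amine or a carboxylic acid. The pair also gives no reason for the large step, and it leaves open whether the same step would appear if the butyl chain or the phenoxyethoxy side chain were different.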